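Swapping a Methyl for a Cyano on the Benzyl Ring

The source may hold more compounds than are shown below. What is called first, only, known or untested is meant among the compounds shown, and "the series" means these compounds.

Of the compounds shown here, two sharing one core have been measured. Compound 1 `Cc1ccccc1CN1CC=C(CCC(=O)NO)C1=O` carries a methyl on its benzyl ring, and in a functional assay on PC-3 cells (Homo sapiens) for inhibition, read by sulforhodamine B assay (on this read-out higher numbers stand for weaker inhibition of growth and lower numbers for stronger inhibition of growth), compound 1 gives 4620 nM. Compound 2 `Cc1ccc(CN2CC=C(CCC(=O)NO)C2=O)cc1` carries the methyl at a different position of the same ring, and in this assay compound 2 gives 4620 nM. Compound 2 thus stands level with compound 1, and the two values lie within the usual scatter of repeated measurements, so nothing separates them.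

Compound 3 `N#Cc1ccc(CN2CC=C(CCC(=O)NO)C2=O)cc1` is the next step: cyano in place of methyl on an aromatic carbon. Among the measured compounds shown here, no measured pair shows what this kind of swap does here, so the expectation rests on compound 2 alone. The step from compound 2 to compound 3 in this assay is estimated to be small, a 1.1-fold higher number from compound 2 to compound 3 (0.03 log units; within the scatter), with no direction beyond the scatter clearly favoured. Compound 3 is therefore expected to give about 5000 nM, with a likely range from 2000 nM to 12000 nM.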

Compound 3, concentration for 50% growth inhibition: > 10000 nM
Compound 3 was reported as a limit (the forecaster's own chance of this, stated with the estimate: 5%); middle value at least 2.0-fold (0.30 log units) away from the limit.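

Compound 1 and compound 2 stand level, so they gave no sign that the group on the benzyl ring matters, whereas cyano in place of methyl, on an aromatic carbon para to a large group, gives a step beyond the scatter in this assay (an at least 2.1-fold higher number from compound 2 to compound 3 (0.33 log units; beyond the scatter)) toward weaker inhibition of growth. A methyl and a cyano are therefore not interchangeable at this place on the ring. Compound 3 is reported only as a limit (> 10000 nM), not as a number, so the step is a minimum and its full size stays unknown: the limit of > 10000 nM in this assay, at which 1 of the 3 values shown sits.

The compounds shown leave open whether this weakening belongs to cyano alone or would also come with other groups here, such as an amine, a carboxylic acid or a chlorine atom. They also do not tell how a cyano would behave where compound 1 carries its methyl.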